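Fluoro in place of chloro: expected effect on cytotoxicity

The source may hold more compounds than are shown below. What is called first, only, known or untested is meant among the compounds shown, and "the series" means these compounds.

Compound 1 `Fc1ccc(-c2n[nH]cc2/C=N/n2c(OCc3ccccc3Cl)n[nH]c2=S)cc1` and compound 2 `Cc1ccccc1COc1n[nH]c(=S)n1/N=C/c1c[nH]nc1-c1ccc(Cl)cc1` differ at two places, so only their two values are set side by side. In a functional assay on HepG2 cells (Homo sapiens) for cytotoxicity, read by MTT assay, with a stated time of 24 h (on this read-out lower numbers stand for stronger inhibition and higher numbers for weaker inhibition), compound 1 gives 71 ug/mL; compound 2 gives 44 ug/mL, the lower of the two numbers, by a gap that lies within the scatter. Compound 3 `Cc1ccccc1COc1n[nH]c(=S)n1/N=C/c1c[nH]nc1-c1ccc(F)cc1` applies to compound 2 the change (fluoro in place of chloro on an aromatic carbon), fluoro in place of chloro on an aromatic carbon. For the measured compounds named here, no measured pair isolates this change; compound 1 carries fluoro there but differs elsewhere too. The step of a 1.3-fold higher number from compound 2 to compound 3 (0.12 log units; within the scatter) is expected to be small, at most a weakening not beyond the scatter. Compound 3 is estimated at 58 ug/mL, range 30 ug/mL to 115 ug/mL.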

Compound 3, half-maximal inhibitory concentration: 48 ug/mL
Compound 3: middle estimate off by 1.2-fold (0.08 log units), on the high side, and the stated range covers the measured number.
By their numbers in this assay, from the lowest: compounds 2, 3 and 1 (each within the scatter of the next).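

In this assay, 4-chlorophenyl to 4-fluorophenyl is now isolated in a single matched pair, and a 1.1-fold higher number from compound 2 to compound 3 (0.04 log units; within the scatter) shows no effect that can be told from the scatter. Compound 3 also isolates a second site, a swap of chloro for methyl on an aromatic carbon, where a 1.5-fold lower number from compound 1 to compound 3 (0.17 log units; within the scatter) again stays within the scatter. Nothing available speaks to a cause for either result. Still open, on these data alone, is whether an amine or a carboxylic acid in place of the halogen on this six-membered aromatic ring would give a step beyond the scatter.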